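The source may report more compounds than this note shows. Statements on the series, on what has been measured and on what is new or still open speak of the compounds shown alone.

Measured compounds:
compound 1 `COc1ccc(Nc2nc(Oc3cccc(NC(=O)C=C(C)C)c3)c3sccc3n2)cc1` — 17600 nM
compound 2 `C/C=C/C(=O)Nc1cccc(Oc2nc(Nc3cccc(OC)c3)nc3ccsc23)c1` — 13100 nM
compound 3 `COc1cccc(Nc2nc(Oc3cccc(NC(=O)C=C(C)C)c3)c3sccc3n2)c1` — 25800 nM

In a functional assay on A-431 cells (Homo sapiens) for inhibition, read by MTT assay, with a stated time of 72 h (a lower number here means a stronger inhibitor, a higher number a weaker inhibitor), compound 3 gives the highest of the three numbers, but its gaps to the others are small: a 1.5-fold higher number from compound 1 to compound 3 (0.17 log units; within the scatter) and a 2.0-fold higher number from compound 2 to compound 3 (0.29 log units; within the scatter) both stay within the usual scatter, so none of the three can be set apart from the others.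

The next compound, compound 4 `COc1ccc(Nc2nc(Oc3cccc(NC(=O)C=C(C)C)c3)c3sccc3n2)cn1`, differs from compound 3 in one place: 6-methoxypyridin-3-yl in place of 3-methoxyphenyl on a nitrogen on an aromatic ring.

Within the data shown here, only one measured step touches this part of the molecule, the change of the methoxyphenyl group on that nitrogen between compound 1 and compound 3, and it moved the number by a 1.5-fold higher number from compound 1 to compound 3 (0.17 log units; within the scatter), within the scatter. The step from compound 2 to compound 3 concerns the group on the carbonyl carbon and says nothing about the aryl on the nitrogen. Among the measured compounds shown here, no measured step shows a pyridine in place of a phenyl at this position, so nothing supports a step beyond the scatter in either direction. Compound 4 is therefore expected to give a number close to that of compound 3, an estimated step of a 1.2-fold lower number from compound 3 to compound 4 (0.07 log units; within the scatter), with a wide range to cover the untested ring change. The estimate for compound 4 in this assay is 22000 nM, ranging from 7000 nM to 70000 nM.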

Compound 4, half-maximal inhibitory concentration: > 50000 nM
Compound 4: a limit, no number; the forecaster's own chance of this, stated with the estimate: 10%; middle value at least 2.2-fold (0.35 log units) away from the limit.
By their numbers in this assay, from the lowest: compounds 2, 1 and 3 (each within the scatter of the next). At a limit, above all of these: compound 4.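

In this assay, compound 4 gives a limit and not a number: the limit of > 50000 nM in this assay, at which 1 of the 4 values shown sits.

Read against the 4-methoxyphenyl group, the change gives an at least 2.8-fold higher number from compound 1 to compound 4 (0.45 log units; beyond the scatter), the first step at this position beyond the scatter; read against the 3-methoxyphenyl group, it gives an at least 1.9-fold higher number from compound 3 to compound 4 (0.28 log units; that floor lies within the scatter), so only a floor is known. The exchange of the two methoxyphenyl groups gave a 1.5-fold higher number from compound 1 to compound 3 (0.17 log units; within the scatter), so this position does not respond alike to every aryl change: so far, only the ring with one hetero atom gives a step beyond the scatter.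

Going by these compounds, the true size of the step remains open, as does whether it holds with prop-1-en-1-yl on the carbonyl carbon. Also open, on these data alone, is how this position responds to an amine or a carboxylic acid on the ring in place of the methoxy group.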